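This account rests on a few compounds, and the source may have more. Where it says the series, first, only, none or still open, it means among the compounds named here.

In an ADME assay on microsomes from liver (Homo sapiens) for metabolic stability, read by LC-MS, using NADPH, with stated times of 10 min and 30 min (a higher number here means faster removal of the compound, a lower number slower removal), compound 1 `CCS(=O)(=O)N[C@@H]1CCCc2c1cncc2N1Cc2cc(Cl)ccc2C1=O` gives < 3.5 mL/min/kg, which is a limit and not a number. In this assay compound 2 `CC(=O)N[C@@H]1CCCc2c1cncc2N1C(=O)c2ccc(Cl)cc2[C@H]1C` gives < 3.5 mL/min/kg, again a limit and not a number. Compound 2 therefore has no exact place in the series, and it cannot be ranked against compound 1. All that can be said so far is the limit of < 3.5 mL/min/kg in this assay, at which 2 of the 2 values shown sit.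

The next compound to be read is compound 3 `CC(=O)N[C@@H]1CCCc2c1cncc2N1Cc2cc(Cl)ccc2C1=O`. It has hydrogen in place of methyl on a saturated ring carbon. Among the measured compounds shown here, the series holds no measured step for this change, or for any other, so the expectation has little to rest on. No step beyond the scatter is expected in this assay, and no direction is favoured. The expectation starts from compound 2, whose < 3.5 mL/min/kg is a limit. Another reading at the limit is the most likely result. The expected change is a number no lower from compound 2 to compound 3 (the limit leaves the size open), which would lie within the scatter. For compound 3 the estimated clearance is 3.5 mL/min/kg, with an expected range from 2 mL/min/kg to 6 mL/min/kg.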

Compound 3, clearance: < 3.5 mL/min/kg
Compound 3: a limit, no number; the forecaster's own chance of this, stated with the estimate: 70%; the middle value lies on the limit itself.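

Compound 3 reads as a limit and not a number in this assay, as do compound 1 and compound 2, so no step to compound 3 can be read from either of them: the limit of < 3.5 mL/min/kg in this assay, at which 3 of the 3 values shown sit.

The compounds shown leave open whether hydrogen in place of methyl on a saturated ring carbon, or acetyl in place of ethylsulfonyl on an amine nitrogen, changes clearance at all.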